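Halogen swap on an inert sulfonyl series

The source may report more compounds than this note shows. Statements on the series, on what has been measured and on what is new or still open speak of the compounds shown alone.

Three compounds were tested in a functional assay on SUP-B15 cells (Homo sapiens) for antiproliferative activity, with a stated time of 72 h; a higher number here means that more compound is needed for the effect, a lower number that less compound is needed. Compound 1 `COc1ccc(-c2cc(=O)c3c(OC)cc(OC)cc3[nH]2)cc1` gave > 62000 nM, a limit of the assay. Compound 2 `COc1ccc(-c2cc(=O)c3c(OC)cc(OC)cc3n2Cc2ccccc2)cc1` gave > 34400 nM, also a limit. Compound 3 `COc1ccc(-c2cc(=O)c3c(OC)cc(OC)cc3n2S(=O)(=O)c2ccc(F)cc2)cc1` gave > 65500 nM, again a limit.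

Compound 3 thus stands at a limit in this assay, as do both other compounds. The steps a step that the two limits leave unreadable from compound 1 to compound 2, a step that the two limits leave unreadable from compound 1 to compound 3 and a step that the two limits leave unreadable from compound 2 to compound 3 are all unreadable, since each pair sits at the limit of > 34400 nM in this assay, at which 1 of the 3 values shown sits, the limit of > 62000 nM in this assay, at which 1 of the 3 values shown sits, or (the limit of > 65500 nM in this assay, at which 1 of the 3 values shown sits). Compound 4 `COc1ccc(-c2cc(=O)c3c(OC)cc(OC)cc3n2S(=O)(=O)c2ccc(Cl)cc2)cc1` differs from compound 3 by chloro in place of fluoro on an aromatic carbon. Going by the values given here, no measured step bears on this change, and nothing in the data points to a readable effect in this assay. Compound 4 is therefore expected to remain at a limit, with a number no higher from compound 3 to compound 4 (the limit leaves the size open); the estimate for compound 4 is 65000 nM.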

Compound 4, half-maximal effective concentration: > 34400 nM
Compound 4: no number, only a limit (the forecaster's own chance of this, stated with the estimate: 85%); the middle value lies beyond the limit too.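

In this assay compound 4 gives > 34400 nM, a limit of the assay, so its steps from compound 1, compound 2 and compound 3 cannot be read. The compounds shown leave open how chloro and fluoro compare on this series.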